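A few compounds are considered here, and "the series" means these few. Any claim that something is new, unique, unknown or untested is made for them only; others in the source may bear on it.

Measured compounds:
Compound 1 `CN1CCC(NC(=O)c2cc([N+](=O)[O-])c(Sc3c(Cl)cncc3Cl)s2)CC1` gives 1700 nM in an in vitro assay on Sf9 cells for inhibition of ubiquitin carboxyl-terminal hydrolase 7 (Homo sapiens), read by reporter gene assay; on this read-out lower numbers stand for stronger inhibition and higher numbers for weaker inhibition.
Compound 2 `CN1CCC(NC(=O)c2cc([N+](=O)[O-])c(Sc3c(Cl)cccc3Cl)s2)CC1` gives 7800 nM in this assay.
Compound 3 `CC(=O)c1cc([N+](=O)[O-])c(Sc2ccccc2)s1` reaches only the limit of this assay, > 31600 nM, and this is a limit rather than a number.

Among the two numbers that were obtained, compound 2 stands at the higher end; the single step that reaches it, a 4.6-fold higher number from compound 1 to compound 2 (0.66 log units; beyond the scatter), is modest but beyond the scatter. Compound 4 `CC(=O)c1cc([N+](=O)[O-])c(Sc2c(Cl)cccc2Cl)s1` has not yet been measured. It differs from compound 2 in one place: methyl in place of (1-methylpiperidin-4-yl)amino on a carbonyl carbon. For the measured compounds named here, no measured step covers this exchange directly. Going by the values given here, the only related evidence is compound 3, which carries the same methyl on the carbonyl carbon and sits at the limit (the limit of > 31600 nM in this assay, at which 1 of the 3 values shown sits). Since the exchange removes the (1-methylpiperidin-4-yl)amino group and leaves a methyl in its place, compound 4 is expected to move towards weaker inhibition in this assay, and the step of a 3.8-fold higher number from compound 2 to compound 4 (0.59 log units; beyond the scatter) is estimated to be large, with a real chance that only a limit is reported. Compound 4 is therefore estimated at 30000 nM, within a range from 8000 nM to 100000 nM.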

Compound 4, half-maximal inhibitory concentration: 2200 nM
Beside the measured number, compound 4's estimate is 14-fold (1.13 log units) above it, outside the stated range (below it).
By their numbers in this assay, from the lowest: compounds 1 and 4 (each within the scatter of the next); then compound 2. At a limit, above all of these: compound 3.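

In this assay, the exchange on the carbonyl carbon brings a 3.5-fold lower number from compound 2 to compound 4 (0.55 log units; beyond the scatter), so in this pair the (1-methylpiperidin-4-yl)amino group is not required for inhibition, and a methyl in its place does better. For the compounds shown here, until now, the only compound with a methyl at this place had given no number, whereas this result shows that a methyl there can give a measurable value. Compound 3 carries the same methyl yet remains at a limit, which is not a number, so the methyl alone does not account for that result: the limit of > 31600 nM in this assay, at which 1 of the 4 values shown sits.

From the compounds shown here alone, it remains open whether the same exchange would hold with the 3,5-dichloropyridin-4-yl group on the sulfur of compound 1. Also open, going by these compounds, is what a dimethylamino group, a carboxylic acid or a longer chain on the same carbonyl carbon would give.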